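The compounds below may be only part of what the source reports. "The series", "measured", "known", "first", "only" and "open" are said of these compounds alone.

Compound 1 `Fc1ccc(C(SCCNC2CCN(Cc3ccccc3)CC2)c2ccc(F)cc2)cc1` carries a benzyl group on the nitrogen of its six-membered ring. Going by the values given here, in an assay on membranes from Cortex for displacement of a labelled ligand from Sigma non-opioid intracellular receptor 1 (Cavia porcellus), read by scintillation counting, with a stated time of 120 min (a lower number here means a stronger inhibitor, a higher number a weaker inhibitor), compound 1 gives 3.81 nM, the second highest of the three numbers measured so far. Compound 2 `O=C(c1ccccc1)N1CCC(NCCSC(c2ccc(F)cc2)c2ccc(F)cc2)CC1` has a benzoyl group in the same place and gives 2.03 nM; the step of a 1.9-fold lower number from compound 1 to compound 2 (0.27 log units; within the scatter) lies within the scatter. Compound 3 `O=C(c1cc2ccccc2o1)N1CCC(NCCSC(c2ccc(F)cc2)c2ccc(F)cc2)CC1` has a (1-benzofuran-2-yl)carbonyl group there and gives 304 nM; the step of an 80-fold higher number from compound 1 to compound 3 (1.90 log units; beyond the scatter) is large. Between the two carbonyl-bearing compounds the step of a 150-fold higher number from compound 2 to compound 3 (2.18 log units; beyond the scatter) is also large.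

Compound 4 `CC(C)(C)C(=O)N1CCC(NCCSC(c2ccc(F)cc2)c2ccc(F)cc2)CC1` has not yet been measured. It differs from compound 1 at the same ring nitrogen: (tert-butyl)carbonyl in place of benzyl on an amine nitrogen in a ring. Both measured steps from compound 1 bear on this change. The step to compound 2 shows that a carbonyl group in this place can leave the number essentially where it was, while the step to compound 3 shows that a larger group with a second ring can raise it greatly. The entering (tert-butyl)carbonyl has no ring at all, so a moderate rise at most seems likely. For compound 4 the estimated value is 8 nM, with a range from 2 nM to 40 nM, which means an expected step of a 2.1-fold higher number from compound 1 to compound 4 (0.32 log units; beyond the scatter).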

Compound 4, inhibition constant: 163 nM
Estimate against measurement, compound 4: 20-fold (1.31 log units) below; the measured number lies above the stated range.
By their numbers in this assay, from the lowest: compounds 2 and 1 (each within the scatter of the next); then compounds 4 and 3 (each within the scatter of the next).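

In this assay, the (tert-butyl)carbonyl group gives a large rise (a 43-fold higher number from compound 1 to compound 4 (1.63 log units; beyond the scatter)), so a carbonyl on this ring nitrogen does not by itself keep the number low, and compound 2 now stands apart from compounds 3 and 4 among the carbonyl-bearing compounds shown. The group on the carbonyl carbon therefore matters greatly here: tert-butyl in place of phenyl also gives a large rise (an 80-fold higher number from compound 2 to compound 4 (1.90 log units; beyond the scatter)), much as 1-benzofuran-2-yl does. Compound 3 and compound 4 cannot be told apart (a 1.9-fold lower number from compound 3 to compound 4 (0.27 log units; within the scatter)), so a second ring is not needed for a high number, and the mere presence or absence of a ring does not sort these compounds, since phenyl in compound 2 and 1-benzofuran-2-yl in compound 3 both carry rings yet lie far apart.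

A cyclohexyl group or a small methyl group on the carbonyl carbon would help show whether the low number of compound 2 depends on the phenyl ring itself or on something a non-aromatic group could also supply. No measurement shown here explains why these three groups on the carbonyl carbon differ as they do.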